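Series notes: aryl swap on the shared core

The source may report more compounds than this note shows. Statements on the series, on what has been measured and on what is new or still open speak of the compounds shown alone.

Two compounds of this series have numbers in a functional assay on MOLT-4 cells (Homo sapiens) for cytotoxicity, read by CCK-8 assay, with a stated time of 72 h (on this read-out higher numbers stand for weaker inhibition and lower numbers for stronger inhibition), so far. Compound 1 `C=CCn1c(=O)/c(=C\c2cc(Br)ccc2F)[nH]c(=O)/c1=C\c1ccccc1OC` gives 12900 nM in this assay. Compound 2 `C=CCn1c(=O)/c(=C\c2cccc(Br)c2)[nH]c(=O)/c1=C\c1ccccc1OC` gives 5000 nM in this assay. Among the measured compounds shown here, the only measured step is a 2.6-fold lower number from compound 1 to compound 2 (0.41 log units; beyond the scatter), which exchanges hydrogen for fluoro on an aromatic carbon. On the numbers shown, compound 2 stands with the lowest of the two values, its nearest neighbour being compound 1.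

Compound 3 `C=CCn1c(=O)/c(=C\c2cccc(Br)c2)[nH]c(=O)/c1=C\c1cccc(Br)c1` is not yet measured. It differs from compound 2 by 3-bromophenyl in place of 2-methoxyphenyl on a double-bonded chain carbon bound to an aromatic carbon. For the measured compounds named here, none of the measured steps touches this position or this kind of exchange; the step from compound 1 to compound 2 concerns a substituent on the other aryl group and gives no guidance here. Going by the values given here, with no comparable step in hand, no direction beyond the scatter can be expected for the step from compound 2 to compound 3, and the estimate is widened accordingly. For compound 3 the expected value in this assay is 4500 nM, with a range from 1200 nM to 17000 nM, which corresponds to an expected step of a 1.1-fold lower number from compound 2 to compound 3 (0.05 log units; within the scatter).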

Compound 3, half-maximal inhibitory concentration: "not active" (no number reported)
Compound 3 has no reported number here, and the estimate cannot be compared.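

Among the compounds shown here, compound 3 is reported as "not active" in this assay with no number, so no step from compound 2 to compound 3 can be read. No available evidence bears on this result. The compounds shown leave open what number, if any, 3-bromophenyl in place of 2-methoxyphenyl would give on this shared core.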